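This account rests on a few compounds, and the source may have more. Where it says the series, first, only, none or still open, it means among the compounds named here.

Measured in a functional assay on CHO-K1 cells for antagonist activity at Orexin receptor type 2 (Homo sapiens), read by FLIPR and calcium flux; on this read-out higher numbers stand for weaker inhibition and lower numbers for stronger inhibition:

Compound 1 `CCOC(=O)c1ccccc1C(=O)N1C[C@H](Oc2cc(C#N)ccn2)CC[C@H]1C` gives 21 nM.
Compound 2 `CC(C)OC(=O)c1ccccc1C(=O)N1C[C@H](Oc2cc(C#N)ccn2)CC[C@H]1C` gives 38 nM.
Compound 3 `CCc1ccnc(O[C@@H]2CC[C@@H](C)N(C(=O)c3ccccc3-n3nccn3)C2)c1` gives 11 nM.

Compound 3 has the lowest number of the three in this assay. Its separation from compound 1 is within the usual scatter, so no order between these two can be claimed; its separation from compound 2 lies beyond the scatter. Among the measured compounds shown here, compound 3 forms no single-change pair with compound 1 or compound 2, so these values show only where it sits.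

For the measured compounds named here, the only single-change step measured so far is a 1.8-fold higher number from compound 1 to compound 2 (0.26 log units; within the scatter), which concerns the ester alkyl group of compound 1 and compound 2 and leaves the pyridine ring untouched.

Compound 4 `Cc1cccc(O[C@@H]2CC[C@@H](C)N(C(=O)c3ccccc3-n3nccn3)C2)n1` differs from compound 3 by 6-methylpyridin-2-yl in place of 4-ethylpyridin-2-yl on an oxygen on a saturated carbon. Going by the values given here, no measured step bears on this change: the pyridine substituent has not been varied anywhere, and compound 1 and compound 2 carry a different group on that ring altogether. The expectation therefore rests on compound 3 alone and carries wide uncertainty. Compound 4 is expected to show a 1.8-fold higher number from compound 3 to compound 4 (0.26 log units; within the scatter), a step of no clear direction and most likely within the scatter. Compound 4 is estimated at 20 nM, with a range from 6 nM to 70 nM.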

Compound 4, half-maximal inhibitory concentration: 33 nM
Estimate against measurement, compound 4: 1.7-fold (0.22 log units) below; low and high end bracket the measured number.
By their numbers in this assay, from the lowest: compounds 3, 1, 4 and 2 (each within the scatter of the next, the first and the last beyond it).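

The pyridine group on the oxygen now has its first measured change: in this assay, 6-methylpyridin-2-yl in place of 4-ethylpyridin-2-yl gives a 3.0-fold higher number from compound 3 to compound 4 (0.48 log units; beyond the scatter). Among the compounds shown here, the only earlier step, a 1.8-fold higher number from compound 1 to compound 2 (0.26 log units; within the scatter), concerned the ester alkyl group and stayed within the scatter, whereas this modest step lies beyond it, showing that the reading can move with the substituent on this ring while the rest of the structure stays fixed. No measurement at hand accounts for the step.

The names 4-ethylpyridin-2-yl and 6-methylpyridin-2-yl differ in both the alkyl group and its ring position, leaving open which of the two matters, a question that 4-methylpyridin-2-yl or 6-ethylpyridin-2-yl on the core of compound 3 would help to separate. Also open, going by these compounds, is how an unsubstituted pyridin-2-yl group, or a pyridine ring carrying an amine or a methoxy group, would read on that same core.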